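Carbonyl aryl swap: oxazolyl for pyrazinyl on the amide

This account rests on a few compounds, and the source may have more. Where it says the series, first, only, none or still open, it means among the compounds named here.

Compound 3 `CCCCNc1nc(N)nc2c1CN(C(=O)c1cnccn1)CC2` gives the highest of the two plain numbers in an assay on HEK293 cells for agonist activity at Toll-like receptor 8 (Homo sapiens), read by a luciferase reporter, with a stated time of 6 h (a higher number here means that more compound is needed for the effect, a lower number that less compound is needed), with 2.2 uM. Compound 1 `CCCCNc1nc(N)nc2c1CN(C(C)=O)CC2` is the nearest, at 0.5 uM, and the step of a 4.4-fold higher number from compound 1 to compound 3 (0.64 log units; beyond the scatter) lies beyond the scatter. Compound 2 `CCCCNc1nc(N)nc2c1CN(C(=O)c1ccncc1)CC2` reports only a limit of this assay, > 25 uM, and the limit of > 25 uM in this assay, at which 1 of the 3 values shown sits, is the boundary at which that value sits. Across the carbonyl substituents the spread is therefore wide: an at least 50-fold higher number from compound 1 to compound 2 (1.69 log units; beyond the scatter) and an at least 11-fold lower number from compound 2 to compound 3 (1.05 log units; beyond the scatter) are both large, while the pyrazin-2-yl amide stays within a modest distance of the acetamide.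

Compound 4 `CCCCNc1nc(N)nc2c1CN(C(=O)c1cocn1)CC2` differs from compound 3 as follows: 1,3-oxazol-4-yl in place of pyrazin-2-yl on a carbonyl carbon. Among the compounds with values here, both rings are aromatic and carry two hydrogen-bond acceptors, so the nearest precedent is the pyrazin-2-yl amide rather than the pyridin-4-yl one. The expected step in this assay is a 1.1-fold higher number from compound 3 to compound 4 (0.06 log units; within the scatter), with no change beyond the scatter. Compound 4 is therefore estimated at 2.5 uM, within a range from 0.6 uM to 12 uM.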

Compound 4, minimum effective concentration: 0.2 uM
The estimate for compound 4 lay 13-fold (1.10 log units) above the measured number, outside the stated range (below it).
By their numbers in this assay, from the lowest: compound 4; then compound 1; then compound 3. At a limit, above all of these: compound 2.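

The carbonyl substituent at this position can be an aromatic ring and still give a lower number than the acetamide in this assay: a 2.5-fold lower number from compound 1 to compound 4 (0.40 log units; beyond the scatter). Aromatic rings with the same hydrogen-bond acceptor and donor counts can also sit far apart here, as the change from six-membered pyrazin-2-yl to five-membered 1,3-oxazol-4-yl gives an 11-fold lower number from compound 3 to compound 4 (1.04 log units; beyond the scatter). The span from the pyridin-4-yl amide reads an at least 120-fold lower number from compound 2 to compound 4 (2.09 log units; beyond the scatter), and its starting point is a limit, not a number: the limit of > 25 uM in this assay, at which 1 of the 4 values shown sits.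

On these data alone, how a 1,3-thiazol-4-yl or a plain phenyl group on the carbonyl would compare with the 1,3-oxazol-4-yl amide remains open. Nothing shown here gives a cause for the step from the pyrazin-2-yl amide.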